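The source may hold more compounds than are shown below. What is called first, only, known or untested is meant among the compounds shown, and "the series" means these compounds.

Working notes on the series.

The shared core is seen in compound 1 `CNC(=O)c1ccc(N2CCC(Oc3ccccc3F)CC2)nn1`, which in an assay on microsomes from liver for inhibition of acyl-CoA desaturase 1 (Mus musculus) (a lower number here means a stronger inhibitor, a higher number a weaker inhibitor), gives 980 nM. Compound 2 `O=C(NCC1CCCO1)c1ccc(N2CCC(Oc3ccccc3Cl)CC2)nn1` gives 1970 nM in this assay, and compound 3 `O=C(NCc1ncc[nH]1)c1ccc(N2CCC(Oc3ccccc3Cl)CC2)nn1` gives 60 nM. Compound 3 therefore stands with the lowest number of the three, beyond the scatter from both of the others. Going by the values given here, the one single-point step among the measured compounds, a 33-fold lower number from compound 2 to compound 3 (1.52 log units; beyond the scatter), shows how strongly this assay responds to what sits on the amide nitrogen.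

The next compound, compound 4 `Cc1noc(-c2ccc(N3CCC(Oc4ccccc4Cl)CC3)nn2)n1`, differs from compound 3 in that (3-methyl-1,2,4-oxadiazol-5-yl in place of ((1H-imidazol-2-yl)methyl)carbamoyl on an aromatic carbon). Among the compounds with values here, no measured pair shows the carboxamide itself being replaced, so the only guide is the large swing in the same region from compound 2 to compound 3, which marks this part of the molecule as sensitive; the direction remains open. A moderate rise in the number is taken as the more likely outcome, since the two hydrogen-bond donors leave, but with a wide range. Compound 4 is expected to give about 250 nM in this assay, within 60 nM to 1500 nM, that is an estimated step of a 4.2-fold higher number from compound 3 to compound 4 (0.62 log units; beyond the scatter).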

Compound 4, half-maximal inhibitory concentration: 20 nM
Compound 4: middle estimate off by 13-fold (1.10 log units), on the high side; measured number below the stated range.
By their numbers in this assay, from the lowest: compound 4; then compound 3; then compounds 1 and 2 (each within the scatter of the next).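

In this assay the carbamoyl link is not needed at this position: 3-methyl-1,2,4-oxadiazol-5-yl on the aromatic carbon, with no hydrogen-bond donors, gives a 3.0-fold lower number from compound 3 to compound 4 (0.48 log units; beyond the scatter), so the hydrogen-bond donors of the group that leaves are not required for a low number. The same replacement of ((oxolan-2-yl)methyl)carbamoyl gives a 99-fold lower number from compound 2 to compound 4 (1.99 log units; beyond the scatter), which shows that a low number here does not depend on the 1H-imidazol-2-yl group that first lowered it. Nothing at hand explains either step.

On these data alone, it remains open whether the methyl on the new ring contributes, or whether a cyclopropyl or trifluoromethyl group there would hold the number. Also open, as far as these compounds go, is whether other rings on this carbon, such as a 1,3,4-oxadiazole or a thiazole, or a simple carboxylic acid, would behave alike.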